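Return to an aryl ketone on the carbonyl carbon

The compounds below may be only part of what the source reports. "The series", "measured", "known", "first", "only" and "open" are said of these compounds alone.

Among the measured compounds shown here, compound 2 `Nc1[nH]c(C(=O)c2ccccc2)c(-c2ccc(Cl)cc2Cl)c1C(=O)c1cccs1` is the weaker of the two measured members: in an assay for inhibition of Polyunsaturated fatty acid lipoxygenase ALOX15 (Homo sapiens), with a stated time of 10 min (a lower number here means a stronger inhibitor, a higher number a weaker inhibitor), compound 2 gives only a limit, > 100000 nM. Compound 1 `Nc1[nH]c(C(=O)c2ccccc2)c(-c2ccc(Cl)cc2Cl)c1C(=O)c1ccc(Cl)c(Cl)c1` gives 12800 nM in this assay. Compound 3 `Nc1[nH]c(C(=O)c2ccccc2)c(-c2ccc(Cl)cc2Cl)c1C(=O)c1cccc(F)c1` differs from compound 2 by 3-fluorophenyl in place of thiophen-2-yl on a carbonyl carbon. For the measured compounds named here, the one measured step, an at least 7.8-fold higher number from compound 1 to compound 2 (0.89 log units; beyond the scatter), ran the other way, from a carbonyl-bound aryl to thiophen-2-yl, and its size is bounded only by the limit of > 100000 nM in this assay, at which 1 of the 2 values shown sits. Restoring a six-membered aromatic ring of carbon only should undo part of that loss, so for compound 3 a lower number is expected, an at least 3.3-fold lower number from compound 2 to compound 3 (0.52 log units; beyond the scatter). Compound 3 is estimated at 30000 nM, within 8000 nM to 100000 nM.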

Compound 3, half-maximal inhibitory concentration: > 100000 nM
Compound 3 gave a limit, no number; the forecaster's own chance of this, stated with the estimate: 35%; middle value at least 3.3-fold (0.52 log units) away from the limit.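

A six-membered aromatic ring of carbon only on the carbonyl carbon is not enough to give a measurable number in this assay: compound 3 stands as a limit, > 100000 nM. Replacing 3,4-dichlorophenyl with 3-fluorophenyl gives an at least 7.8-fold higher number from compound 1 to compound 3 (0.89 log units; beyond the scatter), so among the three groups shown, only 3,4-dichlorophenyl gives a number. The step between the 3-fluorophenyl and thiophen-2-yl compounds cannot be read because both values are limits: the limit of > 100000 nM in this assay, at which 2 of the 3 values shown sit.

Still open, on these data alone, is whether a chlorophenyl or naphthyl group on this carbonyl carbon would give a measurable number.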